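Hydroxy for amino on a thiosemicarbazone aryl ring

The compounds below may be only part of what the source reports. "The series", "measured", "known", "first", "only" and "open" are said of these compounds alone.

Measured compounds:
compound 1 `C/C(=N/NC(=S)N(Cc1ccccc1)Cc1ccccc1)c1ccccc1O` – 160000 nM in an ADME assay on Vero cells (Chlorocebus sabaeus) for cytotoxicity, read by MTT assay, with a stated time of 72 h; a higher number here means that more compound is tolerated, a lower number that less compound is tolerated
compound 2 `C=CCN(CC=C)C(=S)N/N=C(/C)c1ccc(N)cc1` – "not determined" (no result reported) in this assay

Compound 1 gives 160000 nM in this assay. For compound 2 the result in this assay is "not determined" (no result reported), so its standing cannot be stated. Compound 3 `C=CCN(CC=C)C(=S)N/N=C(/C)c1ccc(O)cc1` differs from compound 2 by hydroxy in place of amino on an aromatic carbon. Among the measured compounds shown here, no comparable step between measured compounds is available, so the size of this step in this assay is open; no change beyond the scatter is assumed in either direction. Compound 3 is estimated to give 100000 nM in this assay, within 30000 nM to 300000 nM.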

Compound 3, half-maximal cytotoxic concentration: 216000 nM
Beside the measured number, compound 3's estimate is 2.2-fold (0.33 log units) below it; low and high end bracket the measured number.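

In this assay, among the compounds shown here, compound 2 has no single number, and no step to compound 3 can be read from it. The compounds shown leave open what hydroxy in place of amino does to this read-out. Nothing at hand bears on the result.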